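Shortening the hydroxycarbamoyl chain of compound 1

A few compounds are considered here, and "the series" means these few. Any claim that something is new, unique, unknown or untested is made for them only; others in the source may bear on it.

Going by the values given here, in a functional assay on PC-3 cells (Homo sapiens) for antiproliferative activity, read by sulforhodamine B assay, with a stated time of 48 h (a higher number here means a weaker inhibitor of growth, a lower number a stronger inhibitor of growth), compound 1 (`CC(C)CCc1c(OCCCCCCCC(=O)NO)ccc(CCC(=O)NO)c1O`) gives 1730 nM and compound 2 (`CC(C)CCc1c(OCCCCC(=O)NO)ccc2ccc(=O)oc12`) gives 1940 nM as the only numbers so far, and these two lie within the scatter of each other. Compound 3 (`CC(C)CCc1c(OCCCCC(=O)NO)ccc(CCC(=O)NO)c1O`) has not yet been measured. It differs from compound 1 by hydroxycarbamoyl in place of 3-(hydroxycarbamoyl)propyl on a saturated chain carbon, four bonds along the chain from an oxygen on an aromatic ring. Among the compounds with values here, no measured step shows what this shortening does, so the expectation in this assay is loose: a small move toward a higher number, probably not beyond the scatter. The expected step is a 1.4-fold higher number from compound 1 to compound 3 (0.14 log units; within the scatter) on this estimate. For compound 3 the estimated value of 2400 nM carries an expected range of 900 nM to 6000 nM until a measurement replaces it.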

Compound 3, concentration for 50% growth inhibition: 14400 nM
Compound 3: the middle estimate sits 6.0-fold (0.78 log units) below what was measured, outside the stated range (above it).
By their numbers in this assay, from the lowest: compounds 1 and 2 (each within the scatter of the next); then compound 3.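

In this assay, the length of the chain on the aromatic oxygen matters: hydroxycarbamoyl in place of 3-(hydroxycarbamoyl)propyl, on a saturated chain carbon, four bonds along the chain from an oxygen on an aromatic ring, gives an 8.3-fold higher number from compound 1 to compound 3 (0.92 log units; beyond the scatter). Going by these compounds alone, this is the first single-place step, and it favours the longer chain of compound 1 over the shorter chain of compound 3, though that rests on this one pair. Nothing at hand accounts for the size of this step.

As far as these compounds go, with only these two chain lengths, the shape of the dependence remains open, including whether an intermediate chain keeps the growth inhibition of compound 1 or a longer chain improves on it. Also open, from the compounds shown here alone, is whether a carboxylic acid could stand in place of the terminal hydroxycarbamoyl on this chain.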